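The source may hold more compounds than are shown below. What is called first, only, known or untested is meant among the compounds shown, and "the series" means these compounds.

Measured so far:
- Compound 1, `CCC(C(=O)N[C@@H](CC(=O)O)C(C)=O)n1cc(C(C)(C)C)nc(NCc2nonc2C)c1=O`: 10000 nM
- Compound 2, `CCC(C(=O)N[C@@H](CC(=O)O)C(=O)CSCc1ccccc1)n1ccnc(NCc2cc(C)no2)c1=O`: 3300 nM

Notes on the series. Both numbers come from an assay for inhibition of Caspase-8 (Homo sapiens); on this read-out higher numbers stand for weaker inhibition and lower numbers for stronger inhibition. Compound 1 gives 10000 nM in this assay, compound 2 gives 3300 nM. Compound 2 stands at the lowest of the two numbers; compound 1 is the nearer one, with a higher number that lies beyond the usual scatter. The two compounds differ in more than one place, so the gap between them is not tied to any single change.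

Compound 3, `CCC(C(=O)N[C@@H](CC(=O)O)C(=O)CSCc1ccccc1)n1ccnc(NCCCOC)c1=O`, is not yet measured in this assay. Its difference from compound 2 is computed as 2-methoxyethyl in place of 3-methyl-1,2-oxazol-5-yl on a saturated chain carbon bound to a nitrogen on an aromatic ring.

Nothing measured here bears directly on this exchange. The expectation for this step from compound 2 to compound 3 is a moderate move toward a higher number, a 1.8-fold higher number from compound 2 to compound 3 (0.26 log units; within the scatter), though a result within the scatter would not surprise. Compound 3 is estimated at 6000 nM, with a range from 2000 nM to 18000 nM.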

Compound 3, half-maximal inhibitory concentration: 7650 nM
Beside the measured number, compound 3's estimate is 1.3-fold (0.11 log units) below it; low and high end bracket the measured number.
By their numbers in this assay, from the lowest: compound 2; then compounds 3 and 1 (each within the scatter of the next).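

In this assay the series gains its first comparison that turns on a single place, and the exchange gives a 2.3-fold higher number from compound 2 to compound 3 (0.37 log units; beyond the scatter) as a modest move. The position on a saturated chain carbon bound to a nitrogen on an aromatic ring therefore responds to replacing 3-methyl-1,2-oxazol-5-yl, a five-membered aromatic ring, with 2-methoxyethyl, which has no ring. No supporting data show which part of this exchange accounts for the step, whether the loss of the ring, the hydrogen-bond acceptor count or the heavy atom count.

Still open, going by these compounds, is whether a phenyl ring, a plain butyl chain or a terminal amine at this place would hold or lower the number. Also open, on these data alone, is whether this step carries over to the core of compound 1, which differs from compound 2 in more than one place.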